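Moving from compound 3 to compound 4 in the cytotoxicity series

A few compounds are considered here, and "the series" means these few. Any claim that something is new, unique, unknown or untested is made for them only; others in the source may bear on it.

Compound 3 `C=CCn1c(=O)/c(=C\c2ccc(F)c(Br)c2)[nH]c(=O)/c1=C\c1ccccc1OC` stands without a single number in a functional assay on Huh-7 cells (Homo sapiens) for cytotoxicity, read by CCK-8 assay, with a stated time of 72 h; a higher number here means a weaker inhibitor, a lower number a stronger inhibitor: compound 3 is reported as "not active" (no number reported). Compound 1 `C=CCn1c(=O)/c(=C\c2ccc(Cl)c(Cl)c2)[nH]c(=O)/c1=C\c1ccccc1OC` is likewise reported in this assay as "not active" (no number reported), so two of the three measured compounds have no number. Only compound 2 `C=CCn1c(=O)/c(=C\c2ccccc2C(F)(F)F)[nH]c(=O)/c1=C\c1ccccc1OC` gives a number, and in this assay compound 2 gives 9500 nM. Compound 4 `C=CCn1c(=O)/c(=C\c2cc(F)ccc2C)[nH]c(=O)/c1=C\c1ccccc1OC` carries 5-fluoro-2-methylphenyl in place of 3-bromo-4-fluorophenyl on a double-bonded chain carbon bound to an aromatic carbon. For the measured compounds named here, no step between measured compounds is available, and compound 3 has no number, so no size or direction of step can be stated; compound 4 is expected to sit near compound 2 or again without a number. Compound 4 is estimated at 15000 nM, in the range 5000 nM to 60000 nM.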

Compound 4, half-maximal inhibitory concentration: 5600 nM
Estimate against measurement, compound 4: 2.7-fold (0.43 log units) above, and the stated range covers the measured number.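

In this assay compound 3 is reported as "not active" (no number reported) while compound 4 returns a number, so the 5-fluoro-2-methylphenyl group at this place gives a measurable value where 3-bromo-4-fluorophenyl gives none, and this step cannot be read as a size. The step of a 1.7-fold lower number from compound 2 to compound 4 (0.23 log units; within the scatter) lies within the scatter, so 5-fluoro-2-methylphenyl and 2-(trifluoromethyl)phenyl are not told apart here. No measured evidence accounts for these results.

As far as these compounds go, it remains open whether the methyl or the fluorine of compound 4 matters more for its value. From the compounds shown here alone, how an amine or a carboxylic acid on this phenyl ring would read out also remains open.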